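Dimethylamino for Trifluoromethyl on a Shared Urea Core

The source may hold more compounds than are shown below. What is called first, only, known or untested is meant among the compounds shown, and "the series" means these compounds.

Three ureas built on one shared core have been tested in an ADME assay on Raji cells (Homo sapiens) for cytotoxicity, with a stated time of 72 h; on this read-out higher numbers stand for an effect only at larger amounts of compound and lower numbers for an effect already at smaller amounts. Compound 1 `Cc1cc(NC(=O)Nc2ccc(N(C)C)cc2)c2ccccc2n1` gives only a limit of the assay, > 25000 nM, in this assay. Compound 2 `Cc1cc(NC(=O)Nc2ccc(C(F)(F)F)cc2)c2ccccc2n1` gives 23000 nM in this assay, and compound 3 `Cc1cc(NC(=O)Nc2cccc(C(F)(F)F)c2)c2ccccc2n1` gives 10000 nM, the lowest of the two numbers. How the cores of compound 2 and compound 3 differ is not broken down here. Compound 4 `Cc1cc(NC(=O)Nc2cccc(N(C)C)c2)c2ccccc2n1` has not yet been measured. The change from compound 2 to compound 1, (dimethylamino in place of trifluoromethyl on an aromatic carbon), made an at least 1.0-fold higher number from compound 2 to compound 1 (0.03 log units; that floor lies within the scatter); that end point sits at the limit of > 25000 nM in this assay, at which 1 of the 3 values shown sits. The change from compound 3 to compound 4 is the same kind of change, (dimethylamino in place of trifluoromethyl on an aromatic carbon), though here the group sits meta to a large group rather than para to a large group. Compound 4 is therefore expected to give 18000 nM in this assay, with a likely range from 7000 nM to 40000 nM. The expected step is a 1.8-fold higher number from compound 3 to compound 4 (0.26 log units; within the scatter), and that expectation rests on an at least 1.0-fold higher number from compound 2 to compound 1 (0.03 log units; that floor lies within the scatter) having moved the number no lower.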

Compound 4, half-maximal effective concentration: > 25000 nM
Compound 4 gave a limit, no number (the forecaster's own chance of this, stated with the estimate: 35%); middle value at least 1.3-fold (0.14 log units) from the limit.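

Dimethylamino in place of trifluoromethyl made an at least 2.5-fold higher number from compound 3 to compound 4 (0.39 log units; beyond the scatter) in this assay, so on this core the change moved the number by more than the scatter. Neither core shows the change moving the number lower, which is as far as the direction carries, and the size of the step cannot be carried from one core to the other because both steps are known only as floors: the same change on two cores in this assay, an at least 1.0-fold higher number (0.03 log units; that floor lies within the scatter) from compound 2 to compound 1 and an at least 2.5-fold higher number (0.39 log units; beyond the scatter) from compound 3 to compound 4; the limit leaves it open whether they differ Compound 1 and compound 4 both end at a limit, so how far the change reaches on either core remains unread, and the two cores cannot be ranked by it: the limit of > 25000 nM in this assay, at which 2 of the 4 values shown sit.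

The compounds shown carry only trifluoromethyl or dimethylamino on this aromatic ring, so it stays open whether a primary amine, a nitrile or a carboxylic acid in the same place would give a number or a limit in this assay. On these data alone, it also stays open whether a longer amine chain would follow dimethylamino there.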